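The source may report more compounds than this note shows. Statements on the series, on what has been measured and on what is new or still open speak of the compounds shown alone.

Measured compounds:
Compound 1 `O=C(CCCC1CCN(S(=O)(=O)c2ccccc2C(F)(F)F)CC1)NO` — in a functional assay on HCT-116 cells (Homo sapiens) for inhibition, read by resazurin assay, with a stated time of 5 days (on this read-out lower numbers stand for stronger inhibition of growth and higher numbers for weaker inhibition of growth), compound 1 gives "not determined" (no result reported), meaning no result was reported.
Compound 2 `O=C(CCCC1CCN(S(=O)(=O)c2ccccc2Cl)CC1)NO` — in this assay compound 2 gives 2800 nM.
Compound 3 `COc1cccc(S(=O)(=O)N2CCC(CCCC(=O)NO)CC2)c1` — in this assay compound 3 gives "not determined" (no result reported), meaning no result was reported.

All three compounds share the same core, a piperidine carrying a hydroxamic acid chain at one end and an arylsulfonyl group on the ring nitrogen, and differ only in the substituent on the benzene ring of the sulfonyl group. Among the measured compounds shown here, compound 3 stands without a number in this assay, and compound 1 is in the same position; the only number available in the whole set is the one for compound 2, which carries a chloro group in place of the methoxy group of compound 3. For the measured compounds named here, no step between two measured compounds can be drawn from these data.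

The step from compound 3 to compound 4 `O=C(CCCC1CCN(S(=O)(=O)c2ccccc2)CC1)NO` is the change (hydrogen in place of methoxy on an aromatic carbon). Going by the values given here, no measured pair is at hand on which the size of this step in this assay could be anchored. The expectation is that removing the methoxy group leaves the growth inhibition within the scatter of what a compound of this series shows, or at most weakens it slightly, with no strong direction foreseen.

Compound 4 is expected to give about 4000 nM in this assay, within a range of 1500 nM to 12000 nM.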

Compound 4, concentration for 50% growth inhibition: 2700 nM
The estimate for compound 4 lay 1.5-fold (0.17 log units) above the measured number; the range from low to high includes it.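

With compound 4 the series gains its first readable comparison. In this assay, hydrogen in place of chloro on an aromatic carbon gives a 1.0-fold lower number from compound 2 to compound 4 (0.02 log units; within the scatter), so for this pair the chloro group is not needed for growth inhibition of this size, and compound 4, with its plain phenyl group, gives 2700 nM. Compound 3 has no number in this assay, and the change from 3-methoxyphenyl to phenyl therefore cannot be read, so the result says nothing about the methoxy group itself; nothing available explains the result or bears on it.

The compounds shown leave open whether any group on the benzene ring can move the number in this assay beyond the scatter, as compound 1, with its trifluoromethyl group, also stands without a number, and neither an amine nor a carboxylic acid appears on that ring. They also leave open how a longer chain between the shared core and the hydroxamic acid would compare with the chain that all four compounds carry.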